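The source may report more compounds than this note shows. Statements on the series, on what has been measured and on what is new or still open speak of the compounds shown alone.

Two cores appear here. Compound 1 `C=C(Br)C(=O)Nc1cccc(-c2cn3nc(Cc4cccc(OC)c4)sc3n2)c1` and compound 2 `C=C(Br)C(=O)Nc1cccc(-c2cn3nc(Cc4ccccc4)sc3n2)c1` share one of them, while compound 3 `COc1ccc(-c2nn3cc(-c4cccc(N)c4)nc3s2)cc1OC` and the still unmeasured compound 4 `COc1ccc(-c2nn3cc(-c4cccc(N)c4)nc3s2)cc1` share the other; the difference between the two cores is not broken down here. In a functional assay on CCRF-CEM cells (Homo sapiens) for inhibition, read by cell counting, with a stated time of 3 days (a higher number here means a weaker inhibitor, a lower number a stronger inhibitor), compound 1 gives 3100 nM and compound 2 gives 4200 nM. The change hydrogen in place of methoxy on an aromatic carbon produced a 1.4-fold higher number from compound 1 to compound 2 (0.13 log units; within the scatter). In this assay compound 3 gives 14000 nM, the highest number of the three measured compounds, standing beyond the scatter from both compound 2 and compound 1. The change hydrogen in place of methoxy on an aromatic carbon is the same kind of change as that from compound 1 to compound 2, but not the same: in compound 3 the place is ortho to a methoxy group as well as meta to a large group, whereas in compound 1 it is only meta to a large group. Because a 1.4-fold higher number from compound 1 to compound 2 (0.13 log units; within the scatter) stayed within the scatter, a small step is expected, a 1.3-fold higher number from compound 3 to compound 4 (0.11 log units; within the scatter) in this assay. Compound 4 is thus estimated at 18000 nM, with a range from 7000 nM to 45000 nM.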

Compound 4, half-maximal inhibitory concentration: >= 250000 nM
Compound 4 ended at the assay's limit (the forecaster's own chance of this, stated with the estimate: 15%); at least 13-fold (1.14 log units) between middle value and limit.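

In this assay the change hydrogen in place of methoxy on an aromatic carbon gave an at least 17-fold higher number from compound 3 to compound 4 (1.25 log units; beyond the scatter), and for compound 4 the printed >= 250000 nM is a limit of the assay and not a number. Within the data shown here, the data show that this change, which stayed small on the core of compound 1, did not keep its size on the core of compound 3, though they rest on only two pairs and do not show why the two differ or how large the step on the core of compound 3 truly is. The change did not carry over from one core to the other in this series: the same change on two cores in this assay, a 1.4-fold higher number (0.13 log units; within the scatter) from compound 1 to compound 2 and an at least 17-fold higher number (1.25 log units; beyond the scatter) from compound 3 to compound 4, at least 13-fold (1.11 log units) apart, beyond the scatter of two such steps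

As far as these compounds go, it stays open whether the larger step follows the place, ortho to a methoxy group, or some other part of the difference between the two cores. From the compounds shown here alone, it is also open whether a hydroxyl group or a fluorine atom in that place would hold the number near that of compound 3.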